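Working notes: compound 3 to compound 4

This account rests on a few compounds, and the source may have more. Where it says the series, first, only, none or still open, it means among the compounds named here.

Values from a functional assay on HepG2 cells (Homo sapiens) for cytotoxicity, read by MTT assay, with a stated time of 48 h (a higher number here means a weaker inhibitor, a lower number a stronger inhibitor), are as follows
compound 1 `Cc1ccc(-c2nnc(SCCn3c([N+](=O)[O-])cnc3C)o2)cc1` | 2200 nM
compound 2 `COc1ccccc1-c1nnc(SCCn2c([N+](=O)[O-])cnc2C)o1` | 10000 nM
compound 3 `Cc1ncc([N+](=O)[O-])n1CCSc1nnc(-c2ccccc2F)o1` | 3700 nM

Compound 3 has a 1.7-fold higher number from compound 1 to compound 3 (0.23 log units; within the scatter) on one side and a 2.7-fold lower number from compound 2 to compound 3 (0.43 log units; beyond the scatter) on the other. Still unmeasured, compound 4 `Cc1ncc([N+](=O)[O-])n1CCSc1nnc(-c2ccc(Cl)cc2)o1` differs from compound 3 by 4-chlorophenyl in place of 2-fluorophenyl on an aromatic carbon on an aromatic carbon of the five-membered aromatic ring with 2 nitrogen and 1 oxygen. Going by the values given here, no measured compound carries 4-chlorophenyl. Compound 1 with 4-methylphenyl offers the nearest comparison, and a 1.7-fold higher number from compound 1 to compound 3 (0.23 log units; within the scatter) stays small. The larger 4.5-fold higher number from compound 1 to compound 2 (0.66 log units; beyond the scatter) involves a methoxy group absent from compound 4. In this assay a small move towards lower numbers is therefore expected, with no change beyond the scatter. The expected step is a 1.4-fold lower number from compound 3 to compound 4 (0.15 log units; within the scatter) at this stage. Compound 4 is estimated at 2600 nM with an expected range of 1000 nM to 6500 nM as the likely span.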

Compound 4, half-maximal inhibitory concentration: 7800 nM
Beside the measured number, compound 4's estimate is 3.0-fold (0.48 log units) below it; the measured number lies above the stated range.
By their numbers in this assay, from the lowest: compounds 1 and 3 (each within the scatter of the next); then compounds 4 and 2 (each within the scatter of the next).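

In this assay, 4-chlorophenyl separates from 2-fluorophenyl (a 2.1-fold higher number from compound 3 to compound 4 (0.32 log units; beyond the scatter)), which 4-methylphenyl did not, and chloro in place of methyl alone is enough to shift the number (a 3.5-fold higher number from compound 1 to compound 4 (0.55 log units; beyond the scatter)). A high number at this position therefore does not depend on a methoxy group, since 4-chlorophenyl stays level with 2-methoxyphenyl (a 1.3-fold lower number from compound 2 to compound 4 (0.11 log units; within the scatter)). Nothing available explains these steps.

Still open, as far as these compounds go, is how an amine or a carboxylic acid on the phenyl would read here. Also open, from the compounds shown here alone, is whether one group placed differently on the phenyl would shift the number.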